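Removing One Chloro from the Dichlorophenyl Ether

The compounds below may be only part of what the source reports. "The series", "measured", "known", "first", "only" and "open" are said of these compounds alone.

Compound 3 `NC1=NC2(CCOCC2)N(OCCCOc2cccc(Cl)c2Cl)C(N)=N1` gives 100 nM in a functional assay on A549 cells (Homo sapiens) for antiproliferative activity, read by MTT assay, with a stated time of 72 h (on this read-out higher numbers stand for weaker inhibition and lower numbers for stronger inhibition), the lowest of the three numbers recorded. Its nearest neighbour is compound 1 `NC1=NC2(CCOCC2)N(OCCCOc2cccc(Cl)c2)C(N)=N1` with 150 nM, and the step of a 1.5-fold lower number from compound 1 to compound 3 (0.18 log units; within the scatter) lies within the scatter. Compound 2 `NC1=NC2(CCOCC2)N(OCCCOc2ccc(F)cc2)C(N)=N1` gives 1060 nM, and the step of an 11-fold lower number from compound 2 to compound 3 (1.03 log units; beyond the scatter) is large. Compound 4 `NC1=NC2(CCOCC2)N(OCCCOc2ccccc2Cl)C(N)=N1` differs from compound 3 by hydrogen in place of chloro on an aromatic carbon. Going by the values given here, only the step from compound 1 to compound 3 bears on adding or removing a single chloro on this ring, and it was within the scatter, so the reversal here is expected to give at most a modest rise. Compound 4 is therefore expected to give 200 nM, between 80 nM and 500 nM, a step of a 2.0-fold higher number from compound 3 to compound 4 (0.30 log units; within the scatter) expected to stay close to the scatter.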

Compound 4, half-maximal inhibitory concentration: 2700 nM
Beside the measured number, compound 4's estimate is 14-fold (1.13 log units) below it; the whole stated range lies below it.
By their numbers in this assay, from the lowest: compounds 3 and 1 (each within the scatter of the next); then compound 2; then compound 4.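

Taking this chloro off the 2,3-dichlorophenyl ring gives a 27-fold higher number from compound 3 to compound 4 (1.43 log units; beyond the scatter) in this assay and so counts for far more than the other chloro on the ring, whose addition stayed within the scatter. Where a lone chloro sits matters as well, with an 18-fold higher number from compound 1 to compound 4 (1.26 log units; beyond the scatter) on going from 3-chlorophenyl to 2-chlorophenyl. The 2-chlorophenyl compound also trails the 4-fluorophenyl one, with a 2.5-fold higher number from compound 2 to compound 4 (0.41 log units; beyond the scatter) as a modest step. Nothing measured here gives a reason for these steps. Going by these compounds, whether a bromo or a methyl on this aromatic carbon would keep the low number of compound 3 stays open.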